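Aryl substituent swaps on the shared core

The source may report more compounds than this note shows. Statements on the series, on what has been measured and on what is new or still open speak of the compounds shown alone.

Among the compounds with values here, compound 3 `CC(c1ccc(-c2ccccc2)c(F)c1)c1nnc2n1N=C(c1ccc(C(F)(F)F)cc1)CS2` gives 9400 nM in a functional assay on Huh-7 cells (Homo sapiens) for inhibition, read by sulforhodamine B assay, with a stated time of 72 h (on this read-out lower numbers stand for stronger inhibition and higher numbers for weaker inhibition), the highest of the three numbers measured so far. Compound 1 `CC(c1ccc(-c2ccccc2)c(F)c1)c1nnc2n1N=C(c1ccc(OC(F)(F)F)cc1)CS2` gives 8400 nM in this assay. The step of a 1.1-fold higher number from compound 1 to compound 3 (0.05 log units; within the scatter) is the only one at the same aromatic position. Compound 2 `CC(c1ccc(-c2ccccc2)c(F)c1)c1nnc2n1N=C(c1ccc(Cl)cc1Cl)CS2` gives 3700 nM in this assay. The step of a 2.5-fold higher number from compound 2 to compound 3 (0.40 log units; beyond the scatter) swaps the whole aryl group rather than one substituent. Compound 4 `COc1ccc(C2=Nn3c(nnc3C(C)c3ccc(-c4ccccc4)c(F)c3)SC2)cc1` differs from compound 3 by methoxy in place of trifluoromethyl on an aromatic carbon. Within the data shown here, no measured step covers a methoxy group, and the one substituent swap at this position stayed within the scatter. A step within the scatter, at most a slightly lower number, is therefore expected, a 1.3-fold lower number from compound 3 to compound 4 (0.13 log units; within the scatter). Compound 4 is estimated at 7000 nM, with a range of 3000 nM to 18000 nM.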

Compound 4, half-maximal inhibitory concentration: 4300 nM
For compound 4 the middle estimate is 1.6-fold (0.21 log units) above the measured one; the range from low to high includes it.
By their numbers in this assay, from the lowest: compounds 2, 4, 1 and 3 (each within the scatter of the next, the first and the last beyond it).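

Within the data shown here, on the aromatic carbon para to a large group, methoxy for trifluoromethyl is the only substituent swap beyond the scatter, with a 2.2-fold lower number from compound 3 to compound 4 (0.34 log units; beyond the scatter) here. Methyl in place of trifluoromethyl on the oxygen gives a 2.0-fold lower number from compound 1 to compound 4 (0.29 log units; within the scatter) and stays within the scatter, as does the whole-aryl comparison, with a 1.2-fold higher number from compound 2 to compound 4 (0.07 log units; within the scatter), so 4-methoxyphenyl does not separate from 2,4-dichlorophenyl. Nothing available explains these differences.

Going by these compounds, whether an amine or a carboxylic acid on this carbon would move the number remains open. So does the effect of a longer chain in place of methyl on the oxygen.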